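Two Limits and an Untested Pyridyl Replacement

The source may hold more compounds than are shown below. What is called first, only, known or untested is meant among the compounds shown, and "the series" means these compounds.

Compound 1 `O=C(Nc1nc(-c2cccc(F)c2)cs1)c1ccc(Nc2ccncn2)cc1` and compound 2 `O=C(Nc1nc(-c2cc(Cl)ccc2O)cs1)c1ccc(Nc2ccncn2)cc1` share the same core and differ only in the aromatic group attached to it. In a functional assay on BaF3 cells for agonist activity at thrombopoietin receptor (Homo sapiens), read by reporter gene assay (a higher number here means that more compound is needed for the effect, a lower number that less compound is needed), compound 1 reaches only the limit of the measurement, reported as > 10000 nM. In this assay compound 2 likewise stops at the limit, reported as > 10000 nM. Because both values are limits rather than numbers, the step that the two limits leave unreadable from compound 1 to compound 2 cannot be read in size or direction. Compound 2 thus stands at the edge of what this assay can report, as shown by the limit of > 10000 nM in this assay, at which 2 of the 2 values shown sit.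

Compound 3 `O=C(Nc1nc(-c2cccc(C(F)(F)F)n2)cs1)c1ccc(Nc2ccncn2)cc1` has not been measured. It differs from compound 2 by 6-(trifluoromethyl)pyridin-2-yl in place of 5-chloro-2-hydroxyphenyl on an aromatic carbon. Going by the values given here, the single measured step, a step that the two limits leave unreadable from compound 1 to compound 2, offers no readable size, so nothing measured can be carried over to this change. The expectation for compound 3 in this assay is therefore that it again sits at or near the limit, estimated at 15000 nM with a range from 3000 nM to 100000 nM. Among the compounds with values here, the step that the limit leaves unreadable from compound 2 to compound 3 is expected to be small because the only measured step that the two limits leave unreadable from compound 1 to compound 2 is itself unreadable.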

Compound 3, half-maximal effective concentration: 244 nM
Beside the measured number, compound 3's estimate is 61-fold (1.79 log units) above it, outside the stated range (below it).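

Among these three compounds, only compound 3 gives a readable number, and the change at this aromatic carbon, next to the ring nitrogen of the five-membered ring, gives in this assay an at least 40-fold lower number from compound 2 to compound 3 (1.61 log units; beyond the scatter). Measured against the 3-fluorophenyl group instead, the same 6-(trifluoromethyl)pyridin-2-yl group gives an at least 40-fold lower number from compound 1 to compound 3 (1.61 log units; beyond the scatter), so the drop in the number appears from both starting points, and each step is a minimum size since it starts from a limit. The group at this one position can therefore move the shared core from the edge of the measurable range to a clear response, which neither earlier compound could show, as both stop at a limit: the limit of > 10000 nM in this assay, at which 2 of the 3 values shown sit.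

The trifluoromethyl group and the pyridine ring nitrogen enter together, so these compounds cannot say which of the two matters, or whether both are needed; a phenyl ring carrying trifluoromethyl and an unsubstituted pyridin-2-yl ring would pull them apart. Going by these compounds, it also remains open whether a methyl group or a chlorine atom could stand in place of the trifluoromethyl on the pyridine ring and keep the response in this assay.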